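A few compounds are considered here, and "the series" means these few. Any claim that something is new, unique, unknown or untested is made for them only; others in the source may bear on it.

Working notes on the series. In a functional assay on K562 cells (Homo sapiens) for cytotoxicity, read by trypan blue exclusion, with a stated time of 96 h (on this read-out higher numbers stand for weaker inhibition and lower numbers for stronger inhibition), compound 3 `COc1cc(OC)c(/C=C/S(=O)(=O)Nc2ccc(OC)c(OP(=O)(O)O)c2)c(OC)c1` gives 7.5 nM, the lowest of the three numbers measured. Compound 2 `COc1ccc(/C=C/S(=O)(=O)Nc2c(OC)cc(OC)cc2OC)cc1` gives 2500 nM in this assay, and compound 1 `COc1ccc(NS(=O)(=O)/C=C/c2c(F)c(F)c(F)c(F)c2F)cc1N` gives 75000 nM. The next member is compound 4 `COc1cc(OC)c(/C=C/S(=O)(=O)Nc2ccc(OC)c(NCC(=O)O)c2)c(OC)c1`, which is not yet measured. Its difference from compound 3 is a group of 5 heavy atoms (2 carbon, 1 nitrogen, 2 oxygen; no ring) in place of a group of 5 heavy atoms (4 oxygen, 1 phosphorus; no ring), on an aromatic carbon. Going by the values given here, no step between measured compounds mirrors this exchange, so nothing among the measured values sets its size. The step from compound 3 to compound 4 is expected to go toward a higher number in this assay, moderate in size and beyond the scatter, a 5.3-fold higher number from compound 3 to compound 4 (0.73 log units; beyond the scatter). Compound 4 is therefore estimated at 40 nM, with a likely range from 5 nM to 400 nM.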

Compound 4, half-maximal inhibitory concentration: 20 nM
Beside the measured number, compound 4's estimate is 2.0-fold (0.30 log units) above it; the measured number falls inside the stated range.
By their numbers in this assay, from the lowest: compound 3; then compound 4; then compound 2; then compound 1.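

At this aromatic carbon, ortho to a methoxy group, the group of 4 oxygen and 1 phosphorus atoms can be exchanged for (carboxymethyl)amino in this assay with the step being a 2.7-fold higher number from compound 3 to compound 4 (0.43 log units; beyond the scatter) and staying modest. Going by these compounds alone, this is the first single-place comparison, and it shows that a phosphorus-free group of the same heavy-atom count keeps the number low. Nothing at hand accounts for the size of this step. Still open, going by these compounds, is whether a plain amine, without the carboxylic acid, or a longer chain ending in a carboxylic acid would hold the number at this carbon.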